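Adding a Chloro Group to an Adenosine-Type Ligand

A few compounds are considered here, and "the series" means these few. Any claim that something is new, unique, unknown or untested is made for them only; others in the source may bear on it.

Compound 1 `CNC(=O)OC[C@H]1OC(n2cnc3c(NC4CCOC4)nc(Cl)nc32)[C@H](O)[C@@H]1O`: 96 nM
Compound 2 `CC/N=C(\S)OC[C@H]1OC(n2cnc3c(NC4CCOC4)ncnc32)[C@H](O)[C@@H]1O`: 33 nM

Of the compounds shown here, two have been measured in an assay on DDT1 cells (Cricetulus griseus) for binding affinity to adenosine receptor A1 (Homo sapiens), read by radioligand binding; on this read-out higher numbers stand for weaker inhibition and lower numbers for stronger inhibition. In this assay compound 1 gives 96 nM. Compound 2 gives 33 nM, the lower of the two numbers, and its gap to compound 1 lies beyond the usual scatter. The two compounds differ in more than one place, so the comparison cannot be tied to a single change.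

Compound 3 `CC/N=C(\S)OC[C@H]1OC(n2cnc3c(NC4CCOC4)nc(Cl)nc32)[C@H](O)[C@@H]1O` is not yet measured. It differs from compound 2 by chloro in place of hydrogen on an aromatic carbon. Going by the values given here, no measured pair isolates this change, so no step size is known for it. Since compound 1 also carries a chloro group and still gives a measurable number, compound 3 is expected to stay close to compound 2, with the estimated step of a 1.2-fold higher number from compound 2 to compound 3 (0.08 log units; within the scatter) not clearly beyond the scatter. Compound 3 is estimated at 40 nM, within 15 nM to 110 nM.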

Compound 3, inhibition constant: 55 nM
Compound 3: the middle estimate sits 1.4-fold (0.14 log units) below what was measured; the range from low to high includes it.
By their numbers in this assay, from the lowest: compounds 2, 3 and 1 (each within the scatter of the next, the first and the last beyond it).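

In this assay the swap of hydrogen for chloro on the aromatic carbon between two ring nitrogen atoms gives a 1.7-fold higher number from compound 2 to compound 3 (0.22 log units; within the scatter) and so leaves the two compounds indistinguishable; at this position, a chloro group is tolerated in this pair. With the chloro group held in place, exchanging the group on the oxygen gives a 1.7-fold lower number from compound 1 to compound 3 (0.24 log units; within the scatter) and again separates the pair by no more than the usual scatter of repeated measurements. Nothing measured here explains these values.

Hydrogen and chloro are the only groups shown on this aromatic carbon, so how an amine or a methyl group there would read remains open. A longer chain on the oxygen-linked side group also remains untested among the compounds shown.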